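Trimming the Cyclopentyl Group from an Aromatic Ether

The source may hold more compounds than are shown below. What is called first, only, known or untested is meant among the compounds shown, and "the series" means these compounds.

Of the compounds shown here, two sharing one core have been tested in an assay for inhibition of Polyunsaturated fatty acid 5-lipoxygenase (Homo sapiens), read by spectrophotometry, tested at 20 uM; on this read-out lower numbers stand for less inhibition and higher numbers for more inhibition at the one concentration tested (going by the name of the read-out). Compound 1 `O=C(/C=C/C=C/c1ccc(Cl)cc1)N1CCCCC1` carries a chloro group on an aromatic carbon and gives 14.5% in this assay. Compound 2 `O=C(/C=C/C=C/c1ccc(OC2CCCC2)cc1)N1CCCCC1` carries cyclopentyloxy at that aromatic carbon and gives 16.1%. Among the measured compounds shown here, the only measured step, a number 1.6 percentage points higher from compound 1 to compound 2 (within the scatter), lies within the scatter, so the two results cannot be told apart; compound 2 stands level with compound 1 in this short list of two numbers.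

Compound 3 `O=C(/C=C/C=C/c1ccc(O)cc1)N1CCCCC1` is the next compound: hydrogen in place of cyclopentyl on an oxygen on an aromatic ring. For the measured compounds named here, only the step from compound 1 to compound 2 touches this part of the molecule, and it stayed within the scatter, so there is no sign yet that swapping the group at this place moves the read-out. The step of a number 3.1 percentage points lower from compound 2 to compound 3 (within the scatter) is therefore expected to stay within the scatter. Compound 3 is estimated at 13%, most likely between 3% and 25%.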

Compound 3, a percentage reported as inhibition, at one concentration (the size of the read-out at that concentration, not a potency): 44.4%
Estimate against measurement, compound 3: 31.4 percentage points below; the whole stated range lies below it.
By their numbers in this assay, from the lowest: compounds 1 and 2 (each within the scatter of the next); then compound 3.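

Swapping the group on this aromatic carbon can move the read-out after all: in this assay, replacing cyclopentyl with hydrogen on the oxygen gives a number 28.3 percentage points higher from compound 2 to compound 3 (beyond the scatter). The free hydroxy also separates from chloro, with a number 29.9 percentage points higher from compound 1 to compound 3 (beyond the scatter), so among these three groups hydroxy alone stands apart, while chloro and cyclopentyloxy remain level. No measurement shown here explains why the hydroxy compound differs from the other two.

Open, going by these compounds, is whether the hydrogen on the oxygen is what counts, or simply the absence of cyclopentyl; a methoxy group at this carbon would separate those two readings, and an amine or a carboxylic acid there would show how narrowly the result depends on hydroxy itself. With a single tested concentration, the numbers also leave the potency of compound 3 unknown.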